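The source may report more compounds than this note shows. Statements on the series, on what has been measured and on what is new or still open speak of the compounds shown alone.

Measured compounds in the series:
- compound 1, `C[C@H](O)[C@@H](CCc1cccc(F)c1)n1cnc2c(N)ncnc21`, 1.6 nM
- compound 2, `COC(=O)c1cccc(CC[C@H]([C@H](C)O)n2cnc3c(N)ncnc32)c1`, 2.2 nM
- compound 3, `C[C@H](O)[C@@H](CCc1cccc(C(N)=O)c1)n1cnc2c(N)ncnc21`, 2.9 nM

All three values come from an assay on isolated protein for inhibition of adenosine deaminase (Bos taurus), with a stated time of 5 min; on this read-out lower numbers stand for stronger inhibition and higher numbers for weaker inhibition. The three compounds share one core and differ only in the group on the aromatic carbon. Compound 3 gives the highest of the three numbers, but the steps that reach it, a 1.3-fold higher number from compound 2 to compound 3 (0.12 log units; within the scatter) and a 1.8-fold higher number from compound 1 to compound 3 (0.26 log units; within the scatter), are both within the scatter; no order among the three can be read from these numbers, and the step of a 1.4-fold higher number from compound 1 to compound 2 (0.14 log units; within the scatter) is likewise within the scatter.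

Compound 4, `C[C@H](O)[C@@H](CCc1cccc(C(=O)N2CCCC2)c1)n1cnc2c(N)ncnc21`, is not yet measured in this assay. It differs from compound 3 as follows: pyrrolidin-1-yl in place of amino on a carbonyl carbon. Going by the values given here, the only measured step that bears on this change is the one on the same carbonyl carbon, a 1.3-fold higher number from compound 2 to compound 3 (0.12 log units; within the scatter), which was within the scatter. Among the compounds with values here, nothing among the measured compounds shows a variation at this carbonyl carbon that moved the number beyond the scatter, so the expectation for compound 4 is no step beyond the scatter, perhaps a slightly higher number, a 1.4-fold higher number from compound 3 to compound 4 (0.14 log units; within the scatter). Compound 4 is therefore estimated to give 4 nM in this assay, with a range from 1.5 nM to 12 nM.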

Compound 4, inhibition constant: 2.2 nM
Beside the measured number, compound 4's estimate is 1.8-fold (0.26 log units) above it; the measured number falls inside the stated range.
By their numbers in this assay, from the lowest: compounds 1, 2, 4 and 3 (each within the scatter of the next).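

In this assay, the change from carbamoyl to (pyrrolidin-1-yl)carbonyl puts a five-membered non-aromatic ring on the carbonyl carbon and removes the amide hydrogens, yet the number does not move beyond the scatter (a 1.3-fold lower number from compound 3 to compound 4 (0.12 log units; within the scatter)). The earlier compounds shown here varied this carbonyl carbon only between methoxy and amino; the larger ring now joins them, with pyrrolidin-1-yl in place of methoxy also staying within the scatter (no change at the digits printed from compound 2 to compound 4 (within the scatter)), and the whole (pyrrolidin-1-yl)carbonyl group reads no differently from fluoro on the aromatic carbon (a 1.4-fold higher number from compound 1 to compound 4 (0.14 log units; within the scatter)). The four compounds therefore form one flat set in this read-out, and nothing measured alongside them offers an explanation for that flatness.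

On these data alone, it remains open whether any group at this place can move the number beyond the scatter, for instance a free carboxylic acid on the carbonyl carbon, or a bulkier amide such as the morpholin-4-yl or 4-methylpiperazin-1-yl amide. Also open, as far as these compounds go, is whether a longer chain between the aromatic ring and the carbonyl carbon would keep the number this flat.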